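The source may hold more compounds than are shown below. What is called first, only, known or untested is meant among the compounds shown, and "the series" means these compounds.

Among the compounds with values here, in a functional assay on U-373MG ATCC cells for inhibition, with U373 MG (Homo sapiens) as the target, read by MTT assay, with a stated time of 7 days (on this read-out lower numbers stand for stronger inhibition of growth and higher numbers for weaker inhibition of growth), compound 1 `C[Si](C)(C)Cn1nnc2c(C(N)=O)ncn2c1=O` gives 45600 nM, the only true number among the three compounds measured so far. Compound 2 `COc1ccc(Cn2nnc3c(C(N)=O)ncn3c2=O)c(OC)c1` reads > 50000 nM, which is a limit and not a number. Compound 3 `COc1cc(Cn2nnc3c(C(N)=O)ncn3c2=O)cc(OC)c1OC` reads > 50000 nM, which is also a limit. Compound 4 `NC(=O)c1ncn2c(=O)n(Cc3ccco3)nnc12` keeps the core of compound 1 and changes one group, with furan-2-yl entering on a saturated chain carbon bound to an aromatic nitrogen: a group of 5 heavy atoms (4 carbon, 1 oxygen; one five-membered aromatic ring with 1 hetero atom) in place of a group of 4 heavy atoms (3 carbon, 1 silicon; no ring), on a saturated chain carbon bound to an aromatic nitrogen. Within the data shown here, no measured pair shows this change, so no step beyond the usual scatter is expected in this assay. For compound 4, a reading that is again only a limit would not surprise, because of the limit of > 50000 nM in this assay, at which 2 of the 3 values shown sit. The expected change is a 1.1-fold higher number from compound 1 to compound 4 (0.02 log units; within the scatter). Compound 4 is estimated at 48000 nM, with an expected range of 30000 nM to 75000 nM.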

Compound 4, concentration for 50% growth inhibition: > 50000 nM
Compound 4: a limit, no number; the forecaster's own chance of this, stated with the estimate: 60%; at least 1.0-fold (0.01 log units) between middle value and limit.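

Placing furan-2-yl on the saturated chain carbon bound to an aromatic nitrogen gives an at least 1.0-fold higher number from compound 1 to compound 4 (0.04 log units; that floor lies within the scatter) in this assay. The reading of compound 4 is a limit and not a number, so this step fixes only a floor and cannot show whether this change matters. This is the first aromatic ring at this place to be compared with compound 1 in a single change, and the assay again yields little that can be compared: the limit of > 50000 nM in this assay, at which 3 of the 4 values shown sit.

From the compounds shown here alone, compound 1 gives 45600 nM, and it stays open whether any group at this place gives a clearly lower number. Going by these compounds, how an amine or a longer chain would read here also remains unknown.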